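The source may report more compounds than this note shows. Statements on the series, on what has been measured and on what is new or still open speak of the compounds shown alone.

Compound 1, `Cc1cc(-c2ccc(O)cc2)c2ncc(CSCCc3ccccc3)n2c1`, gives 20 ug/mL in an ADME assay on HEL cells (Homo sapiens) for cytotoxicity, with a stated time of 3 days; a lower number here means that less compound is tolerated, a higher number that more compound is tolerated.
Compound 2, `Cc1cc(-c2cccc([N+](=O)[O-])c2)c2ncc(CSCCc3ccccc3)n2c1`, gives 100 ug/mL in this assay.

Among the measured compounds shown here, compound 2 holds the highest of the two numbers measured so far; its only neighbour is compound 1, and the step of a 5.0-fold higher number from compound 1 to compound 2 (0.70 log units; beyond the scatter) lies beyond the scatter. Compound 3, `COc1ccc(-c2cc(C)cn3c(CSCCc4ccccc4)cnc23)cc1`, has not yet been measured. It differs from compound 2 in one place: 4-methoxyphenyl in place of 3-nitrophenyl on an aromatic carbon. For the measured compounds named here, only one measured step bears on this change, the one from compound 1 to compound 2, which was modest in size and went upward. The new change moves in a different direction, replacing the 3-nitrophenyl with a 4-methoxyphenyl, so a step back toward the level of compound 1 is the most plausible expectation, though of uncertain size. Compound 3 is therefore expected to give 50 ug/mL, in the range 20 ug/mL to 100 ug/mL, a step of a 2.0-fold lower number from compound 2 to compound 3 (0.30 log units; within the scatter).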

Compound 3, minimum cytotoxic concentration: 20 ug/mL
Compound 3: middle estimate off by 2.5-fold (0.40 log units), on the high side; measured number inside the range.
By their numbers in this assay, from the lowest: compounds 1 and 3 (each within the scatter of the next); then compound 2.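

At this aromatic carbon, 4-methoxyphenyl in place of 3-nitrophenyl gives a 5.0-fold lower number from compound 2 to compound 3 (0.70 log units; beyond the scatter) in this assay and so shows that the higher number of compound 2 is not shared by a second aryl group. Methyl in place of hydrogen on the oxygen gives no change at the digits printed from compound 1 to compound 3 (within the scatter) and leaves the 4-hydroxyphenyl and 4-methoxyphenyl compounds with the same number. Among the compounds shown here, of the three compounds, only the one carrying 3-nitrophenyl stands apart, and none goes against this within so small a set.

On these data alone, whether the nitro group itself or its place on the phenyl ring sets compound 2 apart remains open, as 4-nitrophenyl, 3-methoxyphenyl or an aminophenyl group would be needed to separate the two. What lies behind the difference also stays unexplained, with no supporting information available.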